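Two Thiazole Acids and a Phenyl Swap

The source may hold more compounds than are shown below. What is called first, only, known or untested is meant among the compounds shown, and "the series" means these compounds.

Measured so far:
compound 1, `CCOC(=O)c1ccc(-c2nc(-c3ccccc3)c(C)s2)cc1`, 383 nM
compound 2, `CCOCCOc1nc(-c2ccc(C(=O)O)cc2)sc1C`, 141 nM

Both compounds were tested in an assay on isolated protein with retinoic acid receptor gamma (Homo sapiens) as the target, read by TR-FRET, with a stated time of 4 h; on this read-out lower numbers stand for an effect already at smaller amounts and higher numbers for an effect only at larger amounts of compound. Compound 1 gives 383 nM, while compound 2 gives 141 nM, the lowest of the two numbers shown; the gap between compound 2 and compound 1 is beyond the usual scatter. Going by the values given here, no step between compounds differing in a single place is available, so the two values can only be compared as a whole.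

Compound 3, `Cc1sc(-c2ccc(C(=O)O)cc2)nc1-c1ccccc1`, has not yet been measured in this assay. It differs from compound 2 by phenyl in place of 2-ethoxyethoxy on an aromatic carbon. Among the compounds with values here, compound 3 keeps the free carboxylic acid seen in compound 2 and carries the phenyl seen in compound 1, but with no single-point step on record, nothing measured pins down how much the phenyl in place of 2-ethoxyethoxy on an aromatic carbon alters the read-out.

The step from compound 2 to compound 3 is expected to be small, within the scatter or only slightly lower, a 1.4-fold lower number from compound 2 to compound 3 (0.15 log units; within the scatter). Compound 3 is therefore estimated at 100 nM, with a range from 30 nM to 400 nM.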

Compound 3, half-maximal effective concentration: 109 nM
For compound 3 the middle estimate is 1.1-fold (0.04 log units) below the measured one; the measured number falls inside the stated range.
By their numbers in this assay, from the lowest: compounds 3 and 2 (each within the scatter of the next); then compound 1.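

At this aromatic carbon, next to the ring nitrogen, this assay shows a 1.3-fold lower number from compound 2 to compound 3 (0.11 log units; within the scatter) and so does not tell phenyl from 2-ethoxyethoxy, although the two groups share a count of 6 heavy atoms and differ in having a ring or none and in carrying 2 hydrogen-bond acceptors or none. Compound 3 also supplies the single-place comparison that the first two compounds lacked: hydrogen in place of ethyl on the oxygen next to the carbonyl group gives a 3.5-fold lower number from compound 1 to compound 3 (0.55 log units; beyond the scatter) and this modest step lies beyond the scatter, unlike the step at the aromatic carbon. Nothing on hand explains the size of either step.

The compounds shown leave open whether this carbon would tolerate groups of another kind, such as an amine, a cyclohexyl ring or a longer ether chain, as it does phenyl and 2-ethoxyethoxy. They also leave open whether an ethyl ester on the 2-ethoxyethoxy compound, or an amide in place of the carboxylic acid, would move the number as the ester of compound 1 does.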